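The compounds below may be only part of what the source reports. "The series", "measured", "known", "first", "only" and "open" are said of these compounds alone.

Series notes. Compound 2 `CC(C)(C)Cn1cc2c(Cl)nc(NC(=O)c3ccc(C(F)(F)F)cc3)nc2n1` carries a trifluoromethyl on the aromatic ring of its amide. In an assay on CHO cells for displacement of a labelled ligand from adenosine receptor A1 (Homo sapiens), read by scintillation counting, with a stated time of 3 h (on this read-out higher numbers stand for weaker inhibition and lower numbers for stronger inhibition), compound 2 gives > 100000 nM, which is a limit of the assay and not a number. Compound 1 `Cn1cc2c(Cl)nc(NC(=O)c3ccc(F)cc3)nc2n1` gives > 100000 nM in this assay, again a limit. Compound 3 `CCOC(=O)c1nc(NC(=O)c2ccc(C(F)(F)F)cc2)nc2nn(CC(C)(C)C)cc12` gives > 100000 nM, also a limit. Within the data shown here, the only measured single-point step, a step that the two limits leave unreadable from compound 2 to compound 3, is therefore unreadable in size, and all three values sit at the limit of > 100000 nM in this assay, at which 3 of the 3 values shown sit. Compound 4 `CC(C)(C)Cn1cc2c(Cl)nc(NC(=O)c3ccc(F)cc3)nc2n1` differs from compound 2 by fluoro in place of trifluoromethyl on an aromatic carbon, para to a large group. Among the measured compounds shown here, no measured step bears directly on this change; compound 1 carries the same fluoro substituent and sits at a limit. With every measured compound at the limit, compound 4 is expected to remain at the limit as well, with a number no higher from compound 2 to compound 4 (the limit leaves the size open) expected to be no readable step. The estimate for compound 4 is 100000 nM, ranging from 30000 nM to 300000 nM.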

Compound 4, inhibition constant: 16500 nM
Compound 4: the middle estimate sits 6.1-fold (0.78 log units) above what was measured; the measured number lies below the stated range.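

On the aromatic carbon para to a large group, fluoro in place of trifluoromethyl gives an at least 6.0-fold lower number from compound 2 to compound 4 (0.78 log units; beyond the scatter), so in this assay this position affects the result when the neopentyl-type chain with its tert-butyl end is present. With fluoro held constant, tert-butyl in place of hydrogen on a saturated chain carbon bound to an aromatic nitrogen gives an at least 6.0-fold lower number from compound 1 to compound 4 (0.78 log units; beyond the scatter), so the change at this second place also counts. Compound 4 alone gives a number, and neither fluoro alone nor the tert-butyl alone moves a compound off the limit: the limit of > 100000 nM in this assay, at which 3 of the 4 values shown sit.

From the compounds shown here alone, the true size of both steps stays open, and the remaining step cannot be read. Going by these compounds, whether methoxy in place of fluoro, or an amine in place of the chloro, would give a lower number also remains open.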